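Ethoxy in place of methoxy on the pyrazoline series

The source may report more compounds than this note shows. Statements on the series, on what has been measured and on what is new or still open speak of the compounds shown alone.

Two compounds carry measured numbers. Compound 1 `Oc1ccc(C2CC(c3ccccc3)=NN2c2ccc(Cl)cc2)cc1` is the unsubstituted member; in an assay on isolated protein for inhibition of protein kinase C zeta type (Homo sapiens), with a stated time of 4 min, tested at 62.5 uM (on this read-out lower numbers stand for less inhibition and higher numbers for more inhibition at the one concentration tested (going by the name of the read-out)), compound 1 gives 95.6%. Compound 2 `COc1ccccc1C1=NN(c2ccc(Cl)cc2)C(c2ccc(O)cc2)C1` carries a methoxy group on the aromatic carbon, and in this assay compound 2 gives 68.4%. Within the data shown here, the only measured step, a number 27.2 percentage points lower from compound 1 to compound 2 (beyond the scatter), is the sole change in this set. Compound 2 therefore stands lowest of the two numbers, with compound 1 as its nearest neighbour and beyond the scatter above it.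

Compound 3 `CCOc1ccccc1C1=NN(c2ccc(Cl)cc2)C(c2ccc(O)cc2)C1` is not yet measured. It differs from compound 2 in one place: methyl in place of hydrogen on a saturated chain carbon bound to an oxygen on an aromatic ring. Compound 3 thus carries 2-ethoxyphenyl where compound 2 carries 2-methoxyphenyl.

Among the measured compounds shown here, no measured step bears directly on lengthening methyl to ethyl on the oxygen. The step from compound 1 to compound 2 concerns a different change, the entry of the methoxy group itself, and it was modest. With no measured guide for the chain extension, the expected step in this assay from compound 2 to compound 3 is one within the scatter, a number 5.4 percentage points lower from compound 2 to compound 3 (within the scatter), in no settled direction. Compound 3 is therefore estimated at 63% in this assay, expected to lie between 40% and 84%.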

Compound 3, a percentage reported as inhibition, at one concentration (the size of the read-out at that concentration, not a potency): 42.8%
The estimate for compound 3 lay 20.2 percentage points above the measured number, and the stated range covers the measured number.
By their numbers in this assay, from the lowest: compound 3; then compound 2; then compound 1.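

Working notes on the oxygen substituent: in this assay this position is sensitive to a single added methyl on the saturated chain carbon bound to the oxygen, with a number 25.6 percentage points lower from compound 2 to compound 3 (beyond the scatter) as the step for 2-methoxyphenyl to 2-ethoxyphenyl. Among these compounds, the entry of methoxy was therefore not the only change here to lower the number, and the three compounds now fall in the order hydrogen, methoxy, ethoxy, with no compound among them going against that order. Taken whole, the replacement of hydrogen by ethoxy on the aromatic carbon gives a number 52.8 percentage points lower from compound 1 to compound 3 (beyond the scatter) and is the largest change in the set, though nothing measured on these compounds accounts for the size of either step.

A propoxy group or a longer chain on the same oxygen would show whether the downward run continues or levels off, and a free hydroxyl or an amine in place of the ethoxy would show whether the number depends on an alkyl group on the oxygen at all. Going by these compounds, whether the same order holds in any other read-out also stays open, since all three numbers come from one assay at one concentration.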